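A few compounds are considered here, and "the series" means these few. Any claim that something is new, unique, unknown or untested is made for them only; others in the source may bear on it.

In a functional assay on HCT-116 cells (Homo sapiens) for inhibition, read by CCK-8 assay, with a stated time of 72 h, tested at 8 uM (on this read-out lower numbers stand for less inhibition of growth and higher numbers for more inhibition of growth at the one concentration tested), compound 3 `Nc1ccccc1NC(=O)c1ccc(CSc2cccc(F)c2)cc1` gives 81.4%, the second highest of the three numbers recorded. Compound 2 `Cc1ccc(SCc2ccc(C(=O)Nc3ccccc3N)cc2)cc1` gives 84% in this assay. The gap a number 2.6 percentage points lower from compound 2 to compound 3 (within the scatter) lies within the scatter. Compound 1 `Nc1ccccc1NC(=O)c1ccc(CSc2ccc(Br)cc2)cc1` gives 67.7% in this assay. The step of a number 13.7 percentage points higher from compound 1 to compound 3 (beyond the scatter) is beyond the scatter. Compound 4 `Cc1cc(C)cc(SCc2ccc(C(=O)Nc3ccccc3N)cc2)c1` has not yet been measured. It differs from compound 3 in one place: 3,5-dimethylphenyl in place of 3-fluorophenyl on a sulfur. Within the data shown here, two measured steps bear on this change. The step of a number 2.6 percentage points lower from compound 2 to compound 3 (within the scatter) set a 4-methylphenyl ring against the 3-fluorophenyl ring on the sulfur and stayed within the scatter, while a number 16.3 percentage points higher from compound 1 to compound 2 (beyond the scatter) showed that methyl in place of bromo on an aromatic carbon raised the number modestly. Compound 4 carries the 3,5-dimethylphenyl ring, and given a number 16.3 percentage points higher from compound 1 to compound 2 (beyond the scatter) and a number 2.6 percentage points lower from compound 2 to compound 3 (within the scatter), a number close to that of compound 3, or slightly higher, is expected in this assay. Compound 4 is therefore estimated at 83%, with a range from 70% to 93%, so that the step of a number 1.6 percentage points higher from compound 3 to compound 4 (within the scatter) is expected to stay within the scatter.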

Compound 4, percent growth inhibition at one concentration: 72.9%
Compound 4: the middle estimate sits 10.1 percentage points above what was measured; measured number inside the range.
By their numbers in this assay, from the lowest: compounds 1, 4, 3 and 2 (each within the scatter of the next, the first and the last beyond it).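

Two rings bearing methyl groups on the sulfur now stand apart in this assay, with a number 11.1 percentage points lower from compound 2 to compound 4 (beyond the scatter) in the piece, so the presence of methyl on this ring does not by itself hold the number at the level of compound 2. The 3,5-dimethylphenyl ring gives a number 8.5 percentage points lower from compound 3 to compound 4 (within the scatter) and a number 5.2 percentage points higher from compound 1 to compound 4 (within the scatter) as its other two steps, which leaves compound 4 within the scatter of two compounds that lie beyond the scatter of each other. Nothing available explains these differences.

As far as these compounds go, compound 4 differs from compound 2 in both the number and the placing of its methyl groups, so which of these matters stays open. From the compounds shown here alone, how a methoxy group or an amine on this ring would read is also open.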